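Trifluoromethylphenyl Variant on a Series Stuck at the Limit

This account rests on a few compounds, and the source may have more. Where it says the series, first, only, none or still open, it means among the compounds named here.

Compound 1 `Cc1ccccc1-n1nncc1CN1C(=O)C2(C(C#N)=C(N)Oc3c(N)cc4nc5ccccc5nc4c32)c2ccccc21`, compound 2 `Cc1cccc(-n2nncc2CN2C(=O)C3(C(C#N)=C(N)Oc4c(N)cc5nc6ccccc6nc5c43)c3ccccc32)c1` and compound 3 `N#CC1=C(N)Oc2c(N)cc3nc4ccccc4nc3c2C12C(=O)N(Cc1cnnn1-c1ccc(Cl)cc1)c1ccccc12` share one core and differ only in the aryl group carried on an aromatic nitrogen of a five-membered aromatic ring with three nitrogen. In a functional assay on HCT-116 cells (Homo sapiens) for antiproliferative activity, read by MTT assay, with a stated time of 48 h (on this read-out higher numbers stand for weaker inhibition and lower numbers for stronger inhibition), compound 1 gives > 50000 nM, which is a limit of the assay and not a number. Compound 2 likewise gives only a limit, > 50000 nM. Compound 3, the starting point of the step followed here, gives > 50000 nM, again a limit rather than a number. Compound 3 thus sits at the limit of > 50000 nM in this assay, at which 3 of the 3 values shown sit, and the two steps that lead to it, a step that the two limits leave unreadable from compound 1 to compound 3 and a step that the two limits leave unreadable from compound 2 to compound 3, cannot be sized because both ends are limits.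

Compound 4 `N#CC1=C(N)Oc2c(N)cc3nc4ccccc4nc3c2C12C(=O)N(Cc1cnnn1-c1cccc(C(F)(F)F)c1)c1ccccc12` is not yet measured. It differs from compound 3 by 3-(trifluoromethyl)phenyl in place of 4-chlorophenyl on an aromatic nitrogen. Every measured exchange of the aryl group on this nitrogen has left the read-out at the limit, so no direction and no size can be read for the change to compound 4. The step of a number no higher from compound 3 to compound 4 (the limit leaves the size open) is therefore expected to be no larger than the scatter. Compound 4 is expected to give about 50000 nM, within a range from 15000 nM to 200000 nM, most likely reported only as a limit.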

Compound 4, half-maximal inhibitory concentration: 18900 nM
For compound 4 the middle estimate is 2.6-fold (0.42 log units) above the measured one; the range from low to high includes it.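

Among the compounds shown here, the aryl group on this nitrogen turns out to matter in this assay, which the earlier compounds could not show: the exchange of 4-chlorophenyl for 3-(trifluoromethyl)phenyl gives an at least 2.6-fold lower number from compound 3 to compound 4 (0.42 log units; beyond the scatter), and the exchange of 2-methylphenyl for the same group gives an at least 2.6-fold lower number from compound 1 to compound 4 (0.42 log units; beyond the scatter). The smallest of the three changes, trifluoromethyl in place of methyl on an aromatic carbon, gives an at least 2.6-fold lower number from compound 2 to compound 4 (0.42 log units; beyond the scatter), so a change within the aryl group alone is enough to bring the read-out to a real number. All three steps are minimum sizes only, and the true distance remains unknown, as compound 1, compound 2 and compound 3 each rest on a limit and not on a number: the limit of > 50000 nM in this assay, at which 3 of the 4 values shown sit.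

From the compounds shown here alone, whether the lower number follows from the trifluoromethyl group itself or from where it sits stays open, and a 4-(trifluoromethyl)phenyl or 3-chlorophenyl group on the same nitrogen would be needed to separate the two. Also open, going by these compounds, is how a 3-methoxyphenyl or 3-aminophenyl group would read here, and whether any aryl group on this nitrogen can go clearly lower than compound 4.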